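This account rests on a few compounds, and the source may have more. Where it says the series, first, only, none or still open, it means among the compounds named here.

Measured in a functional assay on HepG2 cells (Homo sapiens) for inhibition, read by MTT assay, with a stated time of 48 h; a higher number here means a weaker inhibitor of growth, a lower number a stronger inhibitor of growth:
Compound 1 `COc1ccc2c(c1)c(C1CC(c3ccccc3)=NN1C(=O)c1cccnc1)cn2C`: 5110 nM
Compound 2 `COc1ccc2c(c1)c(C1CC(c3ccccc3)=NN1C(=O)c1ccc(OC)nc1)cn2C`: 1330 nM

Of these two, compound 2 has the lower number, and the gap is beyond the scatter. The next compound, compound 3 `COc1ccc2c(c1)c(C1CC(c3ccc(F)cc3)=NN1C(=O)c1ccc(OC)nc1)cn2C`, keeps everything in compound 2 except for one change, phenyl to 4-fluorophenyl: fluoro in place of hydrogen on an aromatic carbon. This is fluoro in place of hydrogen on an aromatic carbon.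

For the measured compounds named here, only one measured step is available, a 3.8-fold lower number from compound 1 to compound 2 (0.58 log units; beyond the scatter). That step was a methoxy in place of hydrogen at another place in the molecule, so it bears on this change only loosely, as a sign of how modest a single substitution can be in this series. Going by the values given here, no measured step shows what fluoro does here. Little movement is therefore expected in this assay, with no shift beyond the scatter. The expected step is a 1.2-fold lower number from compound 2 to compound 3 (0.06 log units; within the scatter). For compound 3 the estimated value is 1150 nM, with an expected range of 480 nM to 2800 nM.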

Compound 3, concentration for 50% growth inhibition: 220 nM
Compound 3: middle estimate off by 5.2-fold (0.72 log units), on the high side, and the stated range ends above it.
By their numbers in this assay, from the lowest: compound 3; then compound 2; then compound 1.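

The phenyl group, unchanged between compound 1 and compound 2, proves to be a second place in the molecule where a single substitution counts: in this assay fluoro in place of hydrogen on an aromatic carbon, para to a large group, gives a 6.0-fold lower number from compound 2 to compound 3 (0.78 log units; beyond the scatter) on top of the earlier methoxy step, a 3.8-fold lower number from compound 1 to compound 2 (0.58 log units; beyond the scatter) in the same series. One fluorine atom, with no ring and no charge added, is thus enough to move the number beyond the scatter. Nothing available explains why this change has such an effect.

The compounds shown leave open whether chloro, bromo, methoxy or an amine at the same place would do as much as fluoro, and whether fluoro elsewhere on that ring would match it. They also leave open whether the fluoro step depends on the methoxy group already present in compound 2, since fluoro appears here only alongside it.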